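This account rests on a few compounds, and the source may have more. Where it says the series, first, only, none or still open, it means among the compounds named here.

Measured compounds in an assay on cells for inhibition of HSP60/HSP10 (Homo sapiens), with a stated time of 60 min; a lower number here means a stronger inhibitor, a higher number a weaker inhibitor:
- compound 1, `C=Cc1ccc(S(=O)(=O)Nc2ccc3oc(-c4ccccc4)nc3c2)cc1`. In this assay compound 1 is recorded only as a limit, > 100000 nM.
- compound 2, `O=S(=O)(Nc1ccc(-c2nc3ccccc3o2)cc1)c1cccc(O)c1`. In this assay compound 2 gives 62000 nM.
- compound 3, `O=S(=O)(Nc1ccc(-c2nc3cc(NS(=O)(=O)c4cccc(O)c4)ccc3o2)cc1)c1cccc(O)c1`. In this assay compound 3 gives 17000 nM.

Compound 2 holds the highest of the two numbers recorded; the nearest is compound 3, reached by a 3.6-fold lower number from compound 2 to compound 3 (0.56 log units; beyond the scatter). Compound 1 stands apart as a limit rather than a number: the limit of > 100000 nM in this assay, at which 1 of the 3 values shown sits. For the measured compounds named here, the single measured step in the set thus concerns the addition of a second sulfonamide group on an aromatic carbon of the shared core, not the aryl carried by the sulfonyl sulfur.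

Compound 4, `COc1ccccc1S(=O)(=O)Nc1ccc(-c2nc3ccccc3o2)cc1`, differs from compound 2 by 2-methoxyphenyl in place of 3-hydroxyphenyl on a sulfonyl sulfur. Going by the values given here, no measured step touches this place: the step from compound 2 to compound 3 alters a different part of the molecule and gives no guide to exchanging the aryl on the sulfur. The limit of compound 1 likewise involves a different aryl at a different position. With nothing bearing directly on the change, the expectation for compound 4 is a step within the scatter, a 1.0-fold lower number from compound 2 to compound 4 (0.01 log units; within the scatter). Compound 4 is therefore estimated at 60000 nM in this assay. The expected range for compound 4 runs from 15000 nM to 200000 nM. Given that compound 1 came back only as a limit, a limit outcome for compound 4 is also a real possibility.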

Compound 4, half-maximal inhibitory concentration: > 100000 nM
Compound 4 was reported as a limit; the forecaster's own chance of this, stated with the estimate: 30%; at least 1.6-fold (0.22 log units) between middle value and limit.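

The position on the sulfonyl sulfur now has its first reading in this assay: an at least 1.6-fold higher number from compound 2 to compound 4 (0.20 log units; that floor lies within the scatter). Compound 4 is a limit and not a number, so this exchange has a floor but no size, and the floor alone does not separate the two compounds: the limit of > 100000 nM in this assay, at which 2 of the 4 values shown sit. The pair also differs in its count under the group names, with 1 hydrogen-bond donor in 3-hydroxyphenyl and 0 hydrogen-bond donors in 2-methoxyphenyl, but the oxygen substituent and its place on the ring change together here, so this one pair cannot assign the outcome to either.

Still open, on these data alone, is how an aryl on the sulfonyl sulfur carrying an amine or a carboxylic acid would read in this assay, which would show whether this place tolerates anything other than the 3-hydroxyphenyl of compound 2. Also open, as far as these compounds go, is whether the second sulfonamide group, which gives a 3.6-fold lower number from compound 2 to compound 3 (0.56 log units; beyond the scatter), would have any comparable effect on a compound bearing 2-methoxyphenyl on the sulfonyl sulfur.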